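A few compounds are considered here, and "the series" means these few. Any claim that something is new, unique, unknown or untested is made for them only; others in the source may bear on it.

Measured so far in a physicochemical assay for solubility, read by mass spectrometry, in phosphate buffer, with a stated time of 24 h, at pH 7.4; on this read-out higher numbers stand for higher solubility and lower numbers for lower solubility:
compound 1, `CC[C@H](C)C(=O)N1CCC(NC(=O)Nc2ccc(C(F)(F)F)cn2)CC1`, 274 ug/mL
compound 2, `CCOC(=O)N1CCC(NC(=O)Nc2ccc(OC(F)(F)F)c(F)c2)CC1`, 0.35 ug/mL

Compound 2 stands lowest of the two numbers in this assay; its nearest neighbour is compound 1, whose value lies far higher, well beyond the scatter. The two share the urea-linked piperidine core but differ in more than one place, so the gap between them cannot be assigned to a single change.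

Compound 3, `O=C(Nc1ccc(OC(F)(F)F)c(F)c1)NC1CCN(C(=O)C2CCCOC2)CC1`, is not yet measured. It differs from compound 2 at the carbonyl carbon on the ring nitrogen:
oxan-3-yl in place of ethoxy on a carbonyl carbon

Within the data shown here, no step between measured compounds bears on this change, so the expectation rests on the structures alone. A small step from compound 2 to compound 3 is expected, upward if anything, and possibly within the scatter; the step of a 2.9-fold higher number from compound 2 to compound 3 (0.46 log units; beyond the scatter) is the estimate. Compound 3 is expected to give about 1 ug/mL in this assay, within 0.2 ug/mL to 5 ug/mL.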

Compound 3, solubility: 174 ug/mL
Compound 3: the middle estimate sits 170-fold (2.24 log units) below what was measured; the whole stated range lies below it.
By their numbers in this assay, from the lowest: compound 2; then compounds 3 and 1 (each within the scatter of the next).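

In this assay, the carbonyl carbon on the ring nitrogen proves to be a highly sensitive position: oxan-3-yl in place of ethoxy gives a 500-fold higher number from compound 2 to compound 3 (2.70 log units; beyond the scatter) with the rest of the structure unchanged. The earlier pair differed in more than one place, whereas this large step belongs to one change, ethoxycarbonyl to (oxan-3-yl)carbonyl, in which the counts of hydrogen-bond donors and acceptors stay the same and no net charge enters. No measurement in hand explains the step.

The compounds shown leave open whether the step follows the six-membered ring, the oxygen within it, or the change from ethoxycarbonyl itself. A cyclohexyl group or a longer alkoxy chain such as butoxy on the same carbonyl carbon would help separate these readings.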